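This account rests on a few compounds, and the source may have more. Where it says the series, first, only, none or still open, it means among the compounds named here.

The measured compounds and their values:

Compound 1 `O=C(c1cn(-c2ccccc2)nc1-c1cccnc1)N1CCC(Cc2ccccc2)CC1` gives 25300 nM in a functional assay on HeLa cells (Homo sapiens) for cytotoxicity, read by MTT assay, with a stated time of 48 h; on this read-out higher numbers stand for weaker inhibition and lower numbers for stronger inhibition.
Compound 2 `COc1ccc(OC(=O)c2cn(-c3ccccc3)nc2-c2cccnc2)cc1` gives > 100000 nM, which is a limit of the assay and not a number.
Compound 3 `CC(C)c1cccc(OC(=O)c2cn(-c3ccccc3)nc2-c2cccnc2)c1` gives > 100000 nM, also a limit of the assay rather than a number.

Compound 2 thus stands at the upper edge of what this assay can report, and it is not alone there: the limit of > 100000 nM in this assay, at which 2 of the 3 values shown sit. Among the compounds with values here, the only step that touches compound 2 directly is the one from compound 2 to compound 3, which is a step that the two limits leave unreadable from compound 2 to compound 3; it therefore says nothing about how far either compound lies past the limit. Within the data shown here, compound 1, the one compound with a numerical value, differs from compound 2 in more than one place, so no step between them can be read.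

The new compound is compound 4 `Cc1ccc(C(C)C)c(OC(=O)c2cn(-c3ccccc3)nc2-c2cccnc2)c1`. Its change from compound 2 is 2-isopropyl-5-methylphenyl in place of 4-methoxyphenyl on an oxygen next to a carbonyl group. The measured step that bears on this change, from compound 2 to compound 3, is unreadable, and the 3-isopropylphenyl of compound 3 already shares the isopropyl with the group entering in compound 4. The expected step from compound 2 to compound 4 is a number no higher from compound 2 to compound 4 (the limit leaves the size open), meaning no readable movement away from the limit. Compound 4 is therefore estimated at 100000 nM, within 30000 nM to 300000 nM, most probably reported again as a limit.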

Compound 4, half-maximal inhibitory concentration: > 100000 nM
Compound 4 gave a limit, no number; the forecaster's own chance of this, stated with the estimate: 75%; the middle value lies on the limit itself.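

In this assay compound 4 gives > 100000 nM as a limit of the assay and not a number. Within the data shown here, no step among compound 2, compound 3 and compound 4 can be read, for all three sit at the same edge: the limit of > 100000 nM in this assay, at which 3 of the 4 values shown sit.

The compounds shown leave open how far each of the three lies past that limit.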